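The source may report more compounds than this note shows. Statements on the series, on what has been measured and on what is new or still open speak of the compounds shown alone.

In an assay on cells (Oocyte) for negative allosteric modulation of glutamate receptor ionotropic, NMDA 2D (Rattus norvegicus), read by two-electrode voltage clamp (on this read-out lower numbers stand for stronger inhibition and higher numbers for weaker inhibition), compound 1 `O=C(O)CCC(=O)N1N=C(c2c(-c3ccccc3)c3cc(Cl)ccc3[nH]c2=O)CC1c1ccc(Br)cc1` gives 3100 nM. Compound 2 `O=C(O)CCC(=O)N1N=C(c2c(-c3ccc(Br)cc3)c3ccccc3[nH]c2=O)CC1c1ccc(Cl)cc1` gives 290 nM in this assay, the lower of the two numbers, and its gap to compound 1 lies beyond the usual scatter. Compound 3 `Cc1ccc(-c2c(C3=NN(C(=O)CCC(=O)O)C(c4ccc(Cl)cc4)C3)c(=O)[nH]c3ccccc23)cc1` differs from compound 2 by methyl in place of bromo on an aromatic carbon. Within the data shown here, no measured pair shows this change, so the step of a 2.1-fold higher number from compound 2 to compound 3 (0.32 log units; beyond the scatter) is an estimate only and is expected to be small, toward a somewhat higher number or none beyond the scatter. For compound 3 the expected value in this assay is 600 nM, within 200 nM to 2000 nM.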

Compound 3, half-maximal inhibitory concentration: 1400 nM
Beside the measured number, compound 3's estimate is 2.3-fold (0.37 log units) below it; low and high end bracket the measured number.
By their numbers in this assay, from the lowest: compound 2; then compound 3; then compound 1.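

In this assay, among these compounds, the change from 4-bromophenyl to 4-methylphenyl gives a 4.8-fold higher number from compound 2 to compound 3 (0.68 log units; beyond the scatter) and provides the first single-place comparison. This position therefore responds to the exchange of one heavy atom, even though neither group adds a ring, charge, hydrogen-bond donor or hydrogen-bond acceptor. Nothing available explains the step.

As far as these compounds go, it remains open how this position would respond to other groups, such as chloro, methoxy, an amine or a carboxylic acid. The compounds shown also leave open whether the same change gives a similar step when the other substituents differ.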